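Swapping the Aromatic Group on the Shared Core

This account rests on a few compounds, and the source may have more. Where it says the series, first, only, none or still open, it means among the compounds named here.

Measured so far in a functional assay on MCF7 cells (Homo sapiens) for antiproliferative activity, read by sulforhodamine B assay; a lower number here means a stronger inhibitor, a higher number a weaker inhibitor:
- compound 1 `O=C1NC(=O)c2ccc(-c3ccsc3)cc2/C1=C/Nc1ccc(CN2CCCCC2)cc1`: 3400 nM
- compound 2 `O=C1NC(=O)c2ccc(-c3ccc(F)cc3)cc2/C1=C/Nc1ccc(CN2CCCCC2)cc1`: 550 nM

Within the data shown here, compound 2, at 550 nM, holds the lower of the only two numbers available, so it is the stronger inhibitor of this pair. The next structure is compound 3 `O=C1NC(=O)c2ccc(-c3cccc(O)c3)cc2/C1=C/Nc1ccc(CN2CCCCC2)cc1`, and the change is 3-hydroxyphenyl in place of 4-fluorophenyl on an aromatic carbon.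

Among the measured compounds shown here, one measured step bears on this, a 6.2-fold lower number from compound 1 to compound 2 (0.79 log units; beyond the scatter), which is also an exchange of one aromatic group for another on an aromatic carbon. It lies beyond the scatter, so groups of this kind can matter in this assay. For the measured compounds named here, it cannot set a direction here, since no measured compound carries a hydroxy group. A step no larger than that one seems likely, with a slight lean towards a higher number, as compound 2 is the better of just two compounds.

The expected change is a 1.3-fold higher number from compound 2 to compound 3 (0.10 log units; within the scatter). The estimate for compound 3 is 700 nM, with an expected range of 200 nM to 2500 nM.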

Compound 3, half-maximal inhibitory concentration: 2000 nM
Compound 3: the middle estimate sits 2.9-fold (0.46 log units) below what was measured; low and high end bracket the measured number.
By their numbers in this assay, from the lowest: compound 2; then compounds 3 and 1 (each within the scatter of the next).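

In this assay, this position on the shared core now shows a second exchange of aromatic groups that lies beyond the scatter: 3-hydroxyphenyl in place of 4-fluorophenyl gives a 3.6-fold higher number from compound 2 to compound 3 (0.56 log units; beyond the scatter) and so gives up the advantage that compound 2 held. The exchange of thiophen-3-yl for 3-hydroxyphenyl gives a 1.7-fold lower number from compound 1 to compound 3 (0.23 log units; within the scatter) and stays within the scatter, so these two groups cannot be told apart here, while compound 2, with its steps to both others beyond the scatter, is the strongest inhibitor of the three. Nothing available accounts for the advantage of 4-fluorophenyl at this position.

The step from compound 2 to compound 3 replaces the fluorine with a hydroxy group and also moves the substituent to a different place on the ring, so the compounds shown cannot separate the effect of the atom from the effect of its location. They also leave open how an unsubstituted phenyl ring, or a phenyl ring carrying an amine or a carboxylic acid, would compare at this position.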